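The compounds below may be only part of what the source reports. "The series", "measured", "known", "first", "only" and "open" are said of these compounds alone.

In a functional assay on A2780 cells (Homo sapiens) for antiproliferative activity, read by CellTiter-Glo, with a stated time of 72 h (a lower number here means a stronger inhibitor, a higher number a weaker inhibitor), two compounds have been measured:

Compound 1 `C[C@H](NC(=O)c1cccc(F)c1)c1ccc(NC(=O)N2CC(c3ccc(N)nc3)C2)cc1` gives 7.6 nM in this test
Compound 2 `C[C@@H](c1ccc(NC(=O)N2CC(c3cncc(N)c3)C2)cc1)N1Cc2ccccc2C1=O` gives 45 nM in this test

Compound 2 has the higher of the two numbers, which makes it the weaker inhibitor, and its gap to compound 1 lies beyond the usual scatter of repeated measurements.

Compound 3 `C[C@H](NC(=O)c1cccc(F)c1)c1ccc(NC(=O)N2CC(c3cncc(N)c3)C2)cc1` has not yet been measured. Its difference from compound 2 is this: a group of 10 heavy atoms (7 carbon, 1 nitrogen, 1 oxygen, 1 fluorine; one six-membered aromatic ring of carbon only) in place of a group of 10 heavy atoms (8 carbon, 1 nitrogen, 1 oxygen; one five-membered non-aromatic ring with 1 hetero atom, one six-membered aromatic ring of carbon only), on a saturated chain carbon bound to an aromatic carbon and a saturated chain carbon. The swap takes place on a saturated chain carbon bound to an aromatic carbon and a saturated chain carbon. The entering ((3-fluorophenyl)carbonyl)amino group also occurs in compound 1, which gives 7.6 nM with it. This is the only ground for expecting a move towards a lower number in this assay. Among the compounds with values here, no measured pair shows this swap directly, so only a moderate gain is expected and the range is kept wide. The estimate amounts to an expected 3.0-fold lower number from compound 2 to compound 3 (0.48 log units; beyond the scatter) in this test. Compound 3 is estimated at 15 nM within an expected range from 5 nM to 45 nM.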

Compound 3, half-maximal inhibitory concentration: 240 nM
Compound 3: the middle estimate sits 16-fold (1.20 log units) below what was measured; measured number outside the range, above it.
By their numbers in this assay, from the lowest: compound 1; then compound 2; then compound 3.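

In this assay, placing ((3-fluorophenyl)carbonyl)amino on the saturated chain carbon of compound 2 gives a 5.3-fold higher number from compound 2 to compound 3 (0.73 log units; beyond the scatter), so with 5-aminopyridin-3-yl on the saturated ring carbon, this group does not bring the low number seen in compound 1; the group it replaces, with its five-membered non-aromatic ring, does better. The other new step isolates the saturated ring carbon: with ((3-fluorophenyl)carbonyl)amino held constant, 5-aminopyridin-3-yl in place of 6-aminopyridin-3-yl gives a 32-fold higher number from compound 1 to compound 3 (1.50 log units; beyond the scatter), a large change from nothing more than a different placement of the amine on the pyridine, and larger than the step at the chain carbon. No measurement at hand explains either step.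

The compounds shown leave open how the group carried by compound 2 would fare with 6-aminopyridin-3-yl on the saturated ring carbon, so it remains unknown whether the preference at the chain carbon holds with both aminopyridines or reverses with the other one. Also open, from the compounds shown here alone, is what simpler groups would do on the chain carbon, such as a plain benzoylamino group without the fluorine, an acetylamino group or a free amine.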